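Moving a hydroxy on the benzylidene ring of a urea hydrazone

The compounds below may be only part of what the source reports. "The series", "measured", "known", "first", "only" and "open" are said of these compounds alone.

Measured compounds:
Compound 1, `COc1ccc(OC)c(/C=N/NC(=O)Nc2ccc(Oc3ccnc(-c4nncn4CCN(C)C)c3)c(F)c2)c1`, gives 6400 nM in a functional assay on U-87MG ATCC cells (Homo sapiens) for cytotoxicity, read by MTT assay, with a stated time of 72 h; a lower number here means a stronger inhibitor, a higher number a weaker inhibitor.
Compound 3, `CN(C)CCn1cnnc1-c1cc(Oc2ccc(NC(=O)N/N=C/c3ccc(O)c(Br)c3)cc2F)ccn1`, gives 12400 nM in this assay.
Compound 2, `CN(C)CCn1cnnc1-c1cc(Oc2ccc(NC(=O)N/N=C/c3ccc(O)c(O)c3)cc2F)ccn1`, reaches only the limit of this assay, > 100000 nM.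

All three share one core and differ only in the aromatic ring attached to the carbon with a double bond to nitrogen. Compound 2 stands at the weak end of what has been measured: its result is a limit, not a number, as the line the limit of > 100000 nM in this assay, at which 1 of the 3 values shown sits, records. The two steps that reach it are both beyond the scatter: an at least 15-fold higher number from compound 1 to compound 2 (1.19 log units; beyond the scatter), and in the other direction an at least 8.0-fold lower number from compound 2 to compound 3 (0.90 log units; beyond the scatter).

Compound 4, `CN(C)CCn1cnnc1-c1cc(Oc2ccc(NC(=O)N/N=C/c3ccc(O)cc3O)cc2F)ccn1`, is not yet measured. It differs from compound 2 by 2,4-dihydroxyphenyl in place of 3,4-dihydroxyphenyl on a carbon with a double bond to nitrogen; the two have the same atoms, joined differently. Within the data shown here, no measured step involves the 2,4-dihydroxyphenyl group, so the closest guide is that the only dihydroxyphenyl analogue, compound 2, sits at the limit, while the compounds with fewer hydroxy groups, compound 1 and compound 3, give numbers. Keeping both hydroxy groups is therefore expected to leave compound 4 weak, with at best a modest improvement; the expected step is an at least 1.6-fold lower number from compound 2 to compound 4 (0.22 log units; that floor lies within the scatter). For compound 4 the expected value in this assay is 60000 nM, in a range from 20000 nM to 200000 nM.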

Compound 4, half-maximal inhibitory concentration: 15400 nM
Estimate against measurement, compound 4: 3.9-fold (0.59 log units) above; measured number below the stated range.
By their numbers in this assay, from the lowest: compounds 1, 3 and 4 (each within the scatter of the next, the first and the last beyond it). At a limit, above all of these: compound 2.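

Moving one hydroxy on this ring, with the atoms unchanged, gives an at least 6.4-fold lower number from compound 2 to compound 4 (0.81 log units; beyond the scatter), so carrying two hydroxy groups does not by itself put a compound at the limit; their arrangement also counts. Compound 2 holds a limit, not a number, so that step gives only a floor: the limit of > 100000 nM in this assay, at which 1 of the 4 values shown sits. Against the other two rings, compound 4 shows a 1.2-fold higher number from compound 3 to compound 4 (0.09 log units; within the scatter), which leaves that pair level, and a 2.4-fold higher number from compound 1 to compound 4 (0.38 log units; beyond the scatter), a modest step that favours the 2,5-dimethoxyphenyl ring.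

These values cannot tell why the arrangement of the hydroxy groups matters, and two dihydroxyphenyl patterns are too few to give a rule. As far as these compounds go, it also stays open whether an amino group or a carboxylic acid on this ring, in place of a hydroxy, would give a lower number.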